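A few compounds are considered here, and "the series" means these few. Any claim that something is new, unique, unknown or untested is made for them only; others in the source may bear on it.

Measured in an assay on Sf9 cells for inhibition of phosphatidylinositol 4,5-bisphosphate 3-kinase catalytic subunit beta isoform (Homo sapiens), with a stated time of 20 min; on this read-out lower numbers stand for stronger inhibition and higher numbers for weaker inhibition:
compound 1 `C[C@H](Nc1ncnc(N)c1C#N)c1nc2ccc(F)cc2c(C(N)=O)c1-c1ccccc1` gives 3540 nM
compound 2 `CNC(=O)c1c(-c2ccccc2)c([C@H](C)Nc2ncnc(N)c2C#N)nc2ccc(F)cc12` gives 1240 nM
compound 3 `C[C@H](Nc1ncnc(N)c1C#N)c1nc2ccc(F)cc2c(C(=O)N(C)C)c1-c1ccccc1` gives 545 nM

Compound 3 has the lowest number of the three, with compound 2 nearest and compound 1 furthest. For the measured compounds named here, the steps so far run one way: a 2.9-fold lower number from compound 1 to compound 2 (0.46 log units; beyond the scatter), a 2.3-fold lower number from compound 2 to compound 3 (0.36 log units; beyond the scatter), and overall a 6.5-fold lower number from compound 1 to compound 3 (0.81 log units; beyond the scatter).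

Compound 4 `CCNC(=O)c1c(-c2ccccc2)c([C@H](C)Nc2ncnc(N)c2C#N)nc2ccc(F)cc12` differs from compound 3 in one place: ethylamino in place of dimethylamino on a carbonyl carbon. This partly reverses the change that gave a 2.3-fold lower number from compound 2 to compound 3 (0.36 log units; beyond the scatter), since a hydrogen returns to the amide-type nitrogen, while the remaining carbon chain grows by one. Going by the values given here, no measured step isolates a methyl-to-ethyl change on that nitrogen, so the expectation rests on compound 2. Compound 4 is expected to land near compound 2, as a 1.7-fold higher number from compound 3 to compound 4 (0.24 log units; within the scatter). The estimate for compound 4 in this assay is 950 nM, within 380 nM to 2400 nM.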

Compound 4, half-maximal inhibitory concentration: 17000 nM
Compound 4: the middle estimate sits 18-fold (1.25 log units) below what was measured, outside the stated range (above it).
By their numbers in this assay, from the lowest: compound 3; then compound 2; then compound 1; then compound 4.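

In this assay, swapping groups on the carbonyl carbon that carry the same atoms is far from neutral: a 31-fold higher number from compound 3 to compound 4 (1.49 log units; beyond the scatter). Extending the chain on the amide-type nitrogen reverses the earlier trend, with a 14-fold higher number from compound 2 to compound 4 (1.14 log units; beyond the scatter) and a 4.8-fold higher number from compound 1 to compound 4 (0.68 log units; beyond the scatter), so compound 4 goes against the fall in numbers seen through compound 2 and compound 3. Nothing measured here accounts for this reversal.

From the compounds shown here alone, it remains open whether a propylamino group continues the rise seen with ethylamino, and whether diethylamino or pyrrolidine on the carbonyl carbon stays close to dimethylamino.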